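This account rests on a few compounds, and the source may have more. Where it says the series, first, only, none or still open, it means among the compounds named here.

Measured compounds in an assay on cells for agonist activity at ecdysone receptor (Bombyx mori), read by a luciferase reporter, with a stated time of 24 h; on this read-out higher numbers stand for an effect only at larger amounts of compound and lower numbers for an effect already at smaller amounts:
Compound 1, `CC(C)(C)N(NC(=O)c1cccc(Br)c1)C(=O)c1ccccc1Cl`, gives 191 nM.
Compound 2, `CC(C)(C)N(NC(=O)c1ccc(I)cc1)C(=O)c1ccccc1Cl`, gives 7.59 nM.

Among these two numbers compound 2 stands lowest in this assay; compound 1 sits well above it, and the single measured step, a 25-fold lower number from compound 1 to compound 2 (1.40 log units; beyond the scatter), lies beyond the scatter. Compound 3, `CC(C)(C)N(NC(=O)c1cccc(Cl)c1Cl)C(=O)c1ccccc1Cl`, has not yet been measured in this assay. It differs from compound 2 in one place: 2,3-dichlorophenyl in place of 4-iodophenyl on a carbonyl carbon. Within the data shown here, the only step that bears on this change is a 25-fold lower number from compound 1 to compound 2 (1.40 log units; beyond the scatter), which shows that exchanging one halogen-bearing phenyl for another on this carbonyl carbon can shift this assay by a large amount. Among the measured compounds shown here, no measured pair, however, covers 2,3-dichlorophenyl itself, so the direction for compound 3 rests on the fact that the 4-iodophenyl belonging to the lowest number is removed. Compound 3 is therefore expected to give a higher number than compound 2, a step of about a 13-fold higher number from compound 2 to compound 3 (1.12 log units; beyond the scatter), with wide uncertainty. The estimate for compound 3 in this assay is 100 nM, within a range from 20 nM to 600 nM.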

Compound 3, half-maximal effective concentration: 9.33 nM
Compound 3: middle estimate off by 11-fold (1.03 log units), on the high side, and the stated range ends above it.
By their numbers in this assay, from the lowest: compounds 2 and 3 (each within the scatter of the next); then compound 1.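

In this assay, putting 2,3-dichlorophenyl in place of 4-iodophenyl on this carbonyl carbon gives a 1.2-fold higher number from compound 2 to compound 3 (0.09 log units; within the scatter), so the two groups cannot be told apart at this position. Measured against 3-bromophenyl, the same 2,3-dichlorophenyl gives a 20-fold lower number from compound 1 to compound 3 (1.31 log units; beyond the scatter), a step of the same large kind as the one seen with 4-iodophenyl, so the low numbers in this assay are not tied to 4-iodophenyl alone, and among these three compounds it is compound 1 that stands apart. Nothing available explains why these halogen-bearing phenyl groups fall where they do.

The compounds shown all carry halogen on this phenyl, so they leave open whether halogen is needed there at all, and how a methoxy, a nitrile, a carboxylic acid or an amine on the same ring would read in this assay. As far as these compounds go, the rest of the core is the same in all three compounds, so it also remains open whether the large steps seen here would hold on a different core.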